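The source may hold more compounds than are shown below. What is called first, only, known or untested is meant among the compounds shown, and "the series" means these compounds.

Of the compounds shown here, three of a shared core have been measured in a functional assay (plasma) for inhibition, with Oryctolagus cuniculus as the target; a lower number here means a stronger inhibitor, a higher number a weaker inhibitor. Compound 1 `Cc1ccc(S(=O)(=O)N[C@H]2C3CC[C@H](C3)[C@@H]2C/C=C\CCCC(=O)O)cc1` gives 500 nM in this assay. Compound 2 `Cc1ccccc1S(=O)(=O)N[C@H]1C2CC[C@H](C2)[C@@H]1C/C=C\CCCC(=O)O` gives 6200 nM, and compound 3 `COc1ccc(S(=O)(=O)N[C@H]2C3CC[C@H](C3)[C@@H]2C/C=C\CCCC(=O)O)cc1` gives 1700 nM. Among the three, compound 3 holds the second highest number: the step of a 3.4-fold higher number from compound 1 to compound 3 (0.53 log units; beyond the scatter) separates it from compound 1, and the step of a 3.6-fold lower number from compound 2 to compound 3 (0.56 log units; beyond the scatter) separates it from compound 2, both beyond the scatter.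

Compound 4 `CN(C)c1ccc(S(=O)(=O)N[C@H]2C3CC[C@H](C3)[C@@H]2C/C=C\CCCC(=O)O)cc1` is the next compound, and it differs from compound 3 in one place: dimethylamino in place of methoxy on an aromatic carbon. For the measured compounds named here, only one measured step bears on this kind of change, the swap at the same aromatic carbon that takes compound 1 to compound 3, which was modest, a 3.4-fold higher number from compound 1 to compound 3 (0.53 log units; beyond the scatter). The step that takes compound 1 to compound 2 moves a group to a different position and does not speak to a change at the same position. Going by the values given here, with a single modest precedent and no direct example of dimethylamino, a small step in this assay, toward a somewhat higher number, is expected for compound 4, with wide uncertainty. The estimate for compound 4 in this assay is 2500 nM, expected to lie between 800 nM and 8000 nM, which amounts to an expected step of a 1.5-fold higher number from compound 3 to compound 4 (0.17 log units; within the scatter).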

Compound 4, half-maximal inhibitory concentration: 7100 nM
Estimate against measurement, compound 4: 2.8-fold (0.45 log units) below; the range from low to high includes it.
By their numbers in this assay, from the lowest: compound 1; then compound 3; then compounds 2 and 4 (each within the scatter of the next).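

In this assay, the dimethylamino swap adds a second step at this position, para to a large group: a 4.2-fold higher number from compound 3 to compound 4 (0.62 log units; beyond the scatter), and measured against the methyl group the change is larger, a 14-fold higher number from compound 1 to compound 4 (1.15 log units; beyond the scatter). Among these three groups, methyl gives the lowest number, methoxy the next and dimethylamino the highest, a pattern that rests on compound 1, compound 3 and compound 4 alone, while the comparison with the 2-methylphenyl compound shows no separation, a 1.1-fold higher number from compound 2 to compound 4 (0.06 log units; within the scatter), which lies within the scatter. Nothing measured here explains this order.

The compounds shown leave open how a hydrogen, a chlorine or a primary amine at this position would compare with the methyl group. They also leave open whether the same order would hold if the heptenoic acid chain were replaced by a shorter chain.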